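The compounds below may be only part of what the source reports. "The series", "measured", "known", "first", "only" and "open" are said of these compounds alone.

Measured compounds:
compound 1, `O=[N+]([O-])c1ccccc1CSc1nnc(-c2ccc3c(c2)OCCO3)o1`, 32700 nM
compound 2, `Brc1ccccc1CSc1nnc(-c2ccc3c(c2)OCCO3)o1`, 22400 nM
compound 3, `Brc1ccc(CSc2nnc(-c3ccc4c(c3)OCCO4)o2)cc1`, 23600 nM

The three compounds share a core and were tested in a functional assay on HeLa cells (Homo sapiens) for antiproliferative activity, read by MTT assay, with a stated time of 48 h; on this read-out higher numbers stand for weaker inhibition and lower numbers for stronger inhibition. Compound 2 gives 22400 nM, and compound 1 gives 32700 nM. The two are separated by one change, (nitro in place of bromo on an aromatic carbon), and the step it made was a 1.5-fold higher number from compound 2 to compound 1 (0.16 log units; within the scatter). Compound 3 gives 23600 nM. Compound 2 and compound 3 have the same atoms joined differently, the difference being (4-bromophenyl in place of 2-bromophenyl on a saturated chain carbon bound to a sulfur), and the step between them was a 1.1-fold higher number from compound 2 to compound 3 (0.02 log units; within the scatter). All three values therefore sit close together in this assay.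

Compound 4, `O=[N+]([O-])c1ccc(CSc2nnc(-c3ccc4c(c3)OCCO4)o2)cc1`, has not yet been measured in this assay. It differs from compound 3 by nitro in place of bromo on an aromatic carbon. Among the compounds with values here, this is the same kind of change as the one from compound 2 to compound 1, but the place is not the same: in the earlier pair the group sat ortho to a large group, whereas here it sits para to a large group. Within the data shown here, only one example of this kind of change exists among the measured compounds, so the expectation rests on that single step. Because compound 2 to compound 1 showed a 1.5-fold higher number from compound 2 to compound 1 (0.16 log units; within the scatter), the step from compound 3 to compound 4 is expected to be similar, a 1.4-fold higher number from compound 3 to compound 4 (0.16 log units; within the scatter). Compound 4 is therefore estimated to give 34000 nM in this assay, with a plausible range from 17000 nM to 70000 nM.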

Compound 4, half-maximal inhibitory concentration: 27500 nM
Compound 4: the middle estimate sits 1.2-fold (0.09 log units) above what was measured, and the stated range covers the measured number.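

In this assay, putting nitro in place of bromo on an aromatic carbon para to a large group gave a 1.2-fold higher number from compound 3 to compound 4 (0.07 log units; within the scatter). Set beside the same swap in the other pair, the two steps agree: the same change on two cores in this assay, a 1.5-fold higher number (0.16 log units; within the scatter) from compound 2 to compound 1 and a 1.2-fold higher number (0.07 log units; within the scatter) from compound 3 to compound 4, 1.3-fold (0.10 log units) apart, within the scatter of two such steps This shows that, on the two cores tested, the swap left the number within the usual scatter both times and the result carried over from one core to the other; it does not show that nitro and bromo truly differ in this assay, since neither step can be told from no change at all, nor does it show that the agreement would hold on any core beyond these two.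

The compounds shown leave open how an amine or a carboxylic acid would behave on the aromatic ring in place of bromo or nitro, and whether a longer chain in place of the saturated carbon bound to the sulfur would shift the number. As every step shown lies within the scatter, they also leave open which change in this series, if any, would produce a clear step in this assay.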